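Notes on the amide side-chain amine swap across two cores

The source may hold more compounds than are shown below. What is called first, only, known or untested is meant among the compounds shown, and "the series" means these compounds.

Measured compounds in a functional assay on A2780 cells (Homo sapiens) for antiproliferative activity, read by MTT assay, with a stated time of 48 h; a higher number here means a weaker inhibitor, a lower number a stronger inhibitor:
compound 1, `CCNCC(=O)Nc1cc(OC)ccc1C(=O)c1ccc(OC)c2c1C=CC(C)(C)O2`, gives 4090 nM
compound 2, `COc1ccc(C(=O)c2ccc(OC)c3c2C=CC(C)(C)O3)c(NC(=O)CN(C)C)c1`, gives 3990 nM
compound 3, `C=C(c1ccc2c(c1)C=CC(C)(C)O2)c1ccc(OC)cc1NC(=O)CNCC`, gives 1870 nM

Compound 1 and compound 2 share one core, compound 3 carries another. The difference between the two cores is not broken down here. Within the first core, compound 2 differs from compound 1 by dimethylamino in place of ethylamino on a saturated chain carbon bound to a carbonyl carbon. The step is a 1.0-fold lower number from compound 1 to compound 2 (0.01 log units; within the scatter), so on that core the two amines read as equivalent.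

Compound 4, `C=C(c1ccc2c(c1)C=CC(C)(C)O2)c1ccc(OC)cc1NC(=O)CN(C)C`, has not been measured. It differs from compound 3 by dimethylamino in place of ethylamino on a saturated chain carbon bound to a carbonyl carbon, the same change at the same place as in the first pair. Among the measured compounds, compound 3 gives the lowest number, beyond the scatter from compound 1 and from compound 2.

Compound 4 is expected to give a 1.0-fold higher number from compound 3 to compound 4 (0.01 log units; within the scatter), because the corresponding change on the other core was a 1.0-fold lower number from compound 1 to compound 2 (0.01 log units; within the scatter). The estimate for compound 4 in this assay is 1900 nM, with a range from 950 nM to 3800 nM.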

Compound 4, half-maximal inhibitory concentration: 510 nM
Estimate against measurement, compound 4: 3.7-fold (0.57 log units) above; measured number outside the range, below it.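

In this assay, dimethylamino in place of ethylamino on the saturated chain carbon gives a 3.7-fold lower number from compound 3 to compound 4 (0.56 log units; beyond the scatter), whereas on the core of compound 1 the same change stays within the scatter. The change therefore does not carry over at equal size from one core to the other in this series: the same change on two cores in this assay, a 1.0-fold lower number (0.01 log units; within the scatter) from compound 1 to compound 2 and a 3.7-fold lower number (0.56 log units; beyond the scatter) from compound 3 to compound 4, 3.6-fold (0.55 log units) apart, beyond the scatter of two such steps. Within the data shown here, with only one pair on each core and a single assay, this shows that the size of the step differs with the core, but not which part of the core accounts for the gap, nor what size the step would take on a further core.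

Still open, going by these compounds, is whether other amines on the same chain carbon, such as diethylamino, pyrrolidine or morpholine, would show a gap between these two cores like the one seen for dimethylamino and ethylamino. Also open, on these data alone, is whether a primary amino group, or a longer chain carrying the dimethylamino group, would behave the same way on both cores.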